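Butoxy for Benzyl in an Aminoindazole Urea Series

The source may hold more compounds than are shown below. What is called first, only, known or untested is meant among the compounds shown, and "the series" means these compounds.

Compound 1 `O=C(Nc1ccccc1OC(F)(F)F)Nc1n[nH]c2ccccc12`: 37500 nM
Compound 2 `Nc1nn(C(=O)Nc2ccc(Cc3ccccc3)cc2)c2ccccc12`: 1550 nM

Going by the values given here, both compounds have been tested in a functional assay on T47D cells (Homo sapiens) for inhibition, read by sulforhodamine B assay, with a stated time of 48 h; on this read-out lower numbers stand for stronger inhibition of growth and higher numbers for weaker inhibition of growth. Compound 2 stands lowest of the two numbers, and its gap to compound 1 lies beyond the scatter, so compound 2 is the stronger grower inhibitor of the pair. Compound 3 `CCCCOc1ccc(NC(=O)n2nc(N)c3ccccc32)cc1` has not been measured; it differs from compound 2 by butoxy in place of benzyl on an aromatic carbon. Among the compounds with values here, no step of this kind exists among the measured compounds, so the expectation rests on compound 2 alone. A small step toward weaker inhibition, or none beyond the scatter, is expected: a 1.9-fold higher number from compound 2 to compound 3 (0.29 log units; within the scatter). Compound 3 is estimated at 3000 nM, within a range from 1000 nM to 10000 nM.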

Compound 3, concentration for 50% growth inhibition: 14800 nM
Compound 3: middle estimate off by 4.9-fold (0.69 log units), on the low side; the whole stated range lies below it.
By their numbers in this assay, from the lowest: compound 2; then compound 3; then compound 1.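

Putting butoxy in place of benzyl on this aromatic carbon, para to a large group, gives a 9.5-fold higher number from compound 2 to compound 3 (0.98 log units; beyond the scatter) and so weakens inhibition of growth. This position is therefore sensitive to which group it carries, and here the group with a ring, benzyl, outperforms the ringless butoxy chain. Nothing measured here explains this drop.

Still open, going by these compounds, is whether the ring or the oxygen matters more, since the change alters both at once. A phenoxy group or a pentyl chain at this position would help separate the two.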